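A few compounds are considered here, and "the series" means these few. Any claim that something is new, unique, unknown or untested is made for them only; others in the source may bear on it.

Measured compounds in the series:
Compound 1, `CCCCN(CCCN1CCCCC1)c1cc(-c2ccccc2)no1`: in a functional assay for antagonist activity at proteinase-activated receptor 1 (Homo sapiens) (on this read-out higher numbers stand for weaker inhibition and lower numbers for stronger inhibition), compound 1 is reported only as a limit, > 40000 nM.
Compound 2, `c1ccc(-c2cc(N(CCCN3CCCCC3)Cc3cccc4ccccc34)on2)cc1`: in this assay compound 2 gives 500 nM.
Compound 3, `COc1cccc(CN(CCCN2CCC2)c2cc(-c3ccccc3)no2)c1`: in this assay compound 3 is reported only as a limit, > 10000 nM.

Compound 3 thus stands at a limit (the limit of > 10000 nM in this assay, at which 1 of the 3 values shown sits), as does compound 1 at its own limit (the limit of > 40000 nM in this assay, at which 1 of the 3 values shown sits); only compound 2 carries a number. Compound 4, `COc1cccc(CN(CCCN2/C=C\C=C/C=C\C2)c2cc(-c3ccccc3)no2)c1`, differs from compound 3 by a group of 8 heavy atoms (7 carbon, 1 nitrogen; one eight-membered non-aromatic ring with 1 hetero atom) in place of a group of 4 heavy atoms (3 carbon, 1 nitrogen; one four-membered non-aromatic ring with 1 hetero atom), on a saturated chain carbon, three bonds along the chain from a nitrogen on an aromatic ring. For the measured compounds named here, the sole measured step, an at least 80-fold lower number from compound 1 to compound 2 (1.90 log units; beyond the scatter), alters the substituent on the nitrogen on the aromatic ring, not the ring at the chain end, so it does not bear on this change; no measured step touches that ring. No basis for a step beyond the scatter is seen. Compound 4 is therefore expected near 15000 nM, range 4000 nM to 60000 nM, the expected step being a step that the limit leaves unreadable from compound 3 to compound 4, with a fair chance of another limit.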

Compound 4, half-maximal inhibitory concentration: > 10000 nM
Compound 4: no number, only a limit; the forecaster's own chance of this, stated with the estimate: 55%; the middle value is on the limit's open side.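

Compound 3 and compound 4 both stand at a limit, and no step between them can be read: the limit of > 10000 nM in this assay, at which 2 of the 4 values shown sit.

The compounds shown leave open whether the azetidin-1-yl ring and the eight-membered ring at the chain end differ at all in inhibition.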